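Ethoxy added ortho to the ether chain of compound 2

The source may hold more compounds than are shown below. What is called first, only, known or untested is meant among the compounds shown, and "the series" means these compounds.

The measured compounds in a functional assay on PC-3 cells (Homo sapiens) for antiproliferative activity, read by MTT assay, with a stated time of 72 h (on this read-out lower numbers stand for stronger inhibition and higher numbers for weaker inhibition), are:
Compound 1, `O=C1OCC[C@@H]1NC(=S)SCCOc1ccc([N+](=O)[O-])cc1`: compound 1 gives 32500 nM.
Compound 2, `O=C1OCC[C@@H]1NC(=S)SCCOc1ccccc1`: compound 2 gives only a limit, > 64000 nM.
Compound 3, `CC(C)(C)c1ccc(/C=C/C(=O)c2ccc(OCC(=O)N[C@H]3CCOC3=O)cc2)cc1`: compound 3 gives 10600 nM.

Compound 2 stands at the edge of what was measured; its value is a limit of the assay and not a number, and it is the limit of > 64000 nM in this assay, at which 1 of the 3 values shown sits. Within the data shown here, the only single-point step among the measured compounds is an at least 1.9-fold higher number from compound 1 to compound 2 (0.29 log units; that floor lies within the scatter), which involves a nitro group and is described as no more than the ordinary scatter at its floor.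

Compound 4, `CCOc1ccccc1OCCSC(=S)N[C@H]1CCOC1=O`, differs from compound 2 by ethoxy in place of hydrogen on an aromatic carbon. Among the measured compounds shown here, no measured step touches an ethoxy group or an added substituent at that place, so none of the measured steps bears directly on this change. For the measured compounds named here, with the starting point already at a limit and no step in the data pointing to a shift in either direction, no move beyond the scatter is expected in this assay.

The step from compound 2 to compound 4 is therefore expected to be a number no higher from compound 2 to compound 4 (the limit leaves the size open). Compound 4 is estimated at 64000 nM, within a range from 25000 nM to 150000 nM.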

Compound 4, half-maximal inhibitory concentration: 24100 nM
For compound 4 the middle estimate is 2.7-fold (0.42 log units) above the measured one, outside the stated range (below it).
By their numbers in this assay, from the lowest: compound 3; then compounds 4 and 1 (each within the scatter of the next). At a limit, above all of these: compound 2.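

In this assay, ethoxy on an aromatic carbon, ortho to a large group, gives an at least 2.6-fold lower number from compound 2 to compound 4 (0.42 log units; beyond the scatter), so a substituent added to this ring in the thioester-free sense of the word is not needed to be nitro for the number to fall.

Let me state that plainly: this is the first step on this ring shown to lie beyond the scatter, whereas the only earlier step, an at least 1.9-fold higher number from compound 1 to compound 2 (0.29 log units; that floor lies within the scatter), could not be told apart from the scatter at its floor. Compound 2 is only a limit, so the real size of the change stays unknown and the step gives a floor alone, because its starting point is not a number: the limit of > 64000 nM in this assay, at which 1 of the 4 values shown sits.

The compounds shown leave open whether a methoxy group, a longer alkoxy chain or an amine at this same place would lower the number as well, or by how much. They also leave open whether ethoxy would have the same effect on a ring that already carries a nitro group, as in compound 1, or in the different chain of compound 3.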